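A few compounds are considered here, and "the series" means these few. Any claim that something is new, unique, unknown or untested is made for them only; others in the source may bear on it.

Working notes on the series, read in an ADME assay on THP-1 cells (Homo sapiens) for cytotoxicity, read by trypan blue exclusion, with a stated time of 48 h; on this read-out higher numbers stand for weaker inhibition of growth and lower numbers for stronger inhibition of growth. Compound 1 `Cc1cc(CNCc2ccccc2)c(C)n1-c1ccc(Cl)cc1` gives 7.2 ug/mL. Compound 2 `Cc1c(CN2CCN(C3CC4CCC3C4)CC2)cc(-c2ccc(Cl)cc2)n1-c1ccc(Cl)cc1` gives 429 ug/mL, a number higher than that of compound 1 and beyond the scatter from it. Compound 3 `Cc1cc(CNOCc2ccccc2)c(C)n1-c1ccc(F)cc1` gives 292 ug/mL, which lies within the scatter of compound 2, so these two share the upper end of the numbers seen so far.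

Compound 4 `Cc1c(CN2CCN(c3ccccc3)CC2)cc(-c2ccc(Cl)cc2)n1-c1ccc(Cl)cc1` has not yet been measured. It is reached from compound 2 by a group of 6 heavy atoms (6 carbon; one six-membered aromatic ring of carbon only) in place of a group of 7 heavy atoms (7 carbon; 2 five-membered non-aromatic rings of carbon only), on an amine nitrogen in a ring, with phenyl entering on an amine nitrogen in a ring. Among the measured compounds shown here, no measured pair isolates a change of this kind, so the data give no direct size for it. With compound 2 at 429 ug/mL and compound 1 at 7.2 ug/mL, there is more room downward than upward. The expected change is modest and toward a lower number, with an estimated 2.9-fold lower number from compound 2 to compound 4 (0.46 log units; beyond the scatter). For compound 4 the estimated value is 150 ug/mL, with an expected range from 30 ug/mL to 500 ug/mL.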

Compound 4, concentration for 50% growth inhibition: 294 ug/mL
Beside the measured number, compound 4's estimate is 2.0-fold (0.29 log units) below it; the measured number falls inside the stated range.
By their numbers in this assay, from the lowest: compound 1; then compounds 3, 4 and 2 (each within the scatter of the next).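

In this assay, among the compounds shown here, this is the first pair that differs in one place, and it gives a 1.5-fold lower number from compound 2 to compound 4 (0.16 log units; within the scatter), so the number does not separate the two groups. On an amine nitrogen in a ring, phenyl and the group with 2 five-membered non-aromatic rings of carbon stand within the scatter of each other, although one group is aromatic and the other is not. Nothing at hand offers a reason for this result.

Going by these compounds, whether a much smaller group on this nitrogen, such as methyl, would give a step beyond the scatter remains open. The same holds for a longer chain, a phenyl ring carrying a carboxylic acid, or an acetyl group in this place.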